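The source may report more compounds than this note shows. Statements on the series, on what has been measured and on what is new or still open speak of the compounds shown alone.

Compound 1, `CCC/N=C1\S/C(=C\c2ccc(O)c(Cl)c2)C(=O)N1C1CC1`, and compound 2, `CCC/N=C1\S/C(=C\c2ccc(O)cc2)C(=O)N1c1ccccc1C`, share a common core and have both been measured in a physicochemical assay for solubility, measured as kinetic solubility; on this read-out lower numbers stand for lower solubility and higher numbers for higher solubility. In this assay compound 1 gives 79000 nM. In this assay compound 2 gives 79000 nM. Compound 1 therefore stands level with compound 2 at the digits shown; the two values fall within the scatter of one another, so no order can be read from them. Compound 3, `CCC/N=C1\S/C(=C\c2ccc(O)c(Cl)c2)C(=O)N1c1ccccc1O`, has not yet been measured in this assay. It differs from compound 1 in one place: 2-hydroxyphenyl in place of cyclopropyl on an amide-type nitrogen in a ring. No step between two measured compounds isolates this change, so the expectation rests only on the two values at hand, which lie together at the digits shown despite compound 2 carrying an aromatic group on the same nitrogen where compound 1 carries the cyclopropyl. The step of no change at the digits printed from compound 1 to compound 3 (within the scatter) is expected to be none beyond the scatter, with no clear direction. Compound 3 is accordingly estimated at 79000 nM in this assay, within a range from 35000 nM to 160000 nM.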

Compound 3, solubility: 220000 nM
Compound 3: the middle estimate sits 2.8-fold (0.44 log units) below what was measured; measured number above the stated range.
By their numbers in this assay, from the lowest: compounds 1 and 2 (each within the scatter of the next); then compound 3.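

On the amide-type nitrogen of the shared core, exchanging cyclopropyl for 2-hydroxyphenyl in this assay gives a 2.8-fold higher number from compound 1 to compound 3 (0.44 log units; beyond the scatter) as a modest step beyond the scatter. For the compounds shown here, this is the first change confined to this position, and it shows that the position is not indifferent to what it carries: a six-membered aromatic ring with 7 heavy atoms, 1 hydrogen-bond donor and 1 hydrogen-bond acceptor can replace a three-membered ring with 3 heavy atoms, and the number rises rather than falls. The data at hand offer no measured basis for explaining the step.

The change swaps the ring and introduces the hydroxyl in a single move, so these compounds cannot tell how much of the step belongs to the aromatic ring and how much to the hydroxyl. Unsubstituted phenyl or 2-methoxyphenyl on the same nitrogen would separate those two parts, while it remains open whether a carboxylic acid or an amine on that ring would move the number further or not at all.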